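Aryl exchange from compound 2 to compound 3

A few compounds are considered here, and "the series" means these few. Any claim that something is new, unique, unknown or untested is made for them only; others in the source may bear on it.

Going by the values given here, in a functional assay on B16 cells (Mus musculus) for cytotoxicity, read by CCK-8 assay, with a stated time of 24 h (on this read-out higher numbers stand for weaker inhibition and lower numbers for stronger inhibition), compound 1 `COc1ccccc1Oc1c(N)nc(Cc2ccccc2)nc1OCCO` gives 47400 nM and compound 2 `COc1ccc(-c2nc(N)c(Oc3ccccc3OC)c(OCCO)n2)cc1` gives 18100 nM as the lower of the two numbers so far. Compound 3 `COc1ccccc1Oc1c(N)nc(-c2cccc(F)c2)nc1OCCO` has not yet been measured. It carries 3-fluorophenyl in place of 4-methoxyphenyl on an aromatic carbon at the position between two ring nitrogen atoms.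

Among the compounds with values here, the only measured step is a 2.6-fold lower number from compound 1 to compound 2 (0.42 log units; beyond the scatter) (4-methoxyphenyl in place of benzyl, a modest change at the same carbon). Within the data shown here, no measured step exchanges one substituted phenyl for another, so the direction is open and a change within the scatter is expected in this assay for this pair. For compound 3 the estimated value is 21000 nM (expected range 9000 nM to 48000 nM). An expected step of a 1.2-fold higher number from compound 2 to compound 3 (0.06 log units; within the scatter) is estimated.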

Compound 3, half-maximal inhibitory concentration: 20900 nM
The estimate for compound 3 lay 1.0-fold (0.00 log units) above the measured number; low and high end bracket the measured number.
By their numbers in this assay, from the lowest: compounds 2 and 3 (each within the scatter of the next); then compound 1.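

In this assay, going by these compounds alone, the step of a 1.2-fold higher number from compound 2 to compound 3 (0.06 log units; within the scatter) is the first exchange of one directly attached phenyl group for another at the carbon between two ring nitrogen atoms. Within the scatter, this position does not separate 3-fluorophenyl from 4-methoxyphenyl, even though the entering group has no hydrogen-bond acceptor and the leaving group has one. The step of a 2.3-fold lower number from compound 1 to compound 3 (0.36 log units; beyond the scatter) runs in the same direction as the earlier step from benzyl, so compound 1 stays apart from both directly attached phenyl compounds. No measurement here bears on why the two phenyl groups read alike.

Open, on these data alone, is whether a pyridyl group, or a phenyl group carrying a carboxylic acid, at this carbon would move the number beyond the scatter. Also open, as far as these compounds go, is how an amine or a longer chain in place of the 2-hydroxyethoxy group, which is shared by all three compounds, would read.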